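The compounds below may be only part of what the source reports. "The series", "measured", "known", "first", "only" and "open" are said of these compounds alone.

Series to date: compound 1 `CCn1c(-c2ccccc2)nc2c(NC3CCCCC3)ncnc21`, compound 2 `Cn1c(-c2cccc(Cl)c2)nc2c(NC3CCCC3)ncnc21`, compound 3 `CCn1c(-c2ccccc2)nc2c(NC3CCOC3)ncnc21`; compound 4 `Cc1cccc(-c2nc3c(NC4CCCC4)ncnc3n2C)c1` awaits measurement. In an assay on CHO cells for displacement of a labelled ligand from adenosine receptor A3 (Homo sapiens), read by scintillation counting, with a stated time of 3 h (a lower number here means a stronger inhibitor, a higher number a weaker inhibitor), compound 2 gives 514 nM. Compound 1 gives 707 nM in this assay, within the scatter of compound 2, while compound 3 gives 1660 nM, beyond it. Within the data shown here, the only single-point step measured, a 2.3-fold higher number from compound 1 to compound 3 (0.37 log units; beyond the scatter), concerns the group on the amine nitrogen, not the aromatic ring. Compound 4 differs from compound 2 by methyl in place of chloro on an aromatic carbon. Among the measured compounds shown here, no measured step touches this position; compounds 1 and 2 differ in several places at once, so their values say nothing clean about the chloro group. The expected step, a 1.1-fold higher number from compound 2 to compound 4 (0.03 log units; within the scatter), is no larger than the scatter. For compound 4 in this assay a value of 550 nM is expected, between 250 nM and 1300 nM.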

Compound 4, inhibition constant: 510 nM
Estimate against measurement, compound 4: 1.1-fold (0.03 log units) above, within the range that was stated.
By their numbers in this assay, from the lowest: compounds 4, 2 and 1 (each within the scatter of the next); then compound 3.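

In this assay the step of a 1.0-fold lower number from compound 2 to compound 4 (0.00 log units; within the scatter) lies within the scatter, so 3-chlorophenyl and 3-methylphenyl cannot be told apart in this series. Among these compounds, this is the first clean reading at this position, since compounds 1 and 2 differ in several places at once. No supporting data bear on this result.

Open, from the compounds shown here alone, is how an amine, a carboxylic acid or a methoxy group would read on this aromatic carbon. Also open, going by these compounds, is whether chloro and methyl still match with a group other than cyclopentyl on the amine nitrogen.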